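Removing a Methoxy Group from the Fused Ring System

The compounds below may be only part of what the source reports. "The series", "measured", "known", "first", "only" and "open" are said of these compounds alone.

Two members of this series have been tested. In a functional assay on NCI-H23 cells (Homo sapiens) for inhibition, read by sulforhodamine B assay, with a stated time of 48 h (on this read-out lower numbers stand for stronger inhibition of growth and higher numbers for weaker inhibition of growth), compound 1 `COc1ccc(-c2[nH]c3ccccc3c2/C=C(\C#N)S(=O)(=O)c2ccccc2)cc1` gives 932 nM. In this assay compound 2 `COc1ccc2[nH]c(-c3ccccc3)c(/C=C(\C#N)S(=O)(=O)c3ccccc3)c2c1` gives 8000 nM, the higher of the two numbers, and the gap between these two values lies beyond the scatter of the method. Compound 3 `N#C/C(=C\c1c(-c2ccccc2)[nH]c2ccccc12)S(=O)(=O)c1ccccc1` has not yet been measured. It differs from compound 2 in one place: hydrogen in place of methoxy on an aromatic carbon, meta and para to a fused ring. For the measured compounds named here, no measured pair in this set reports that exact change, so the size of the step is open. Compound 3 is expected to fall at 2500 nM, within a range from 600 nM to 10000 nM. The step from compound 2 to compound 3 is thus estimated as a 3.2-fold lower number from compound 2 to compound 3 (0.51 log units; beyond the scatter), a move toward lower numbers, though the range allows none beyond the scatter.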

Compound 3, concentration for 50% growth inhibition: 4700 nM
The estimate for compound 3 lay 1.9-fold (0.27 log units) below the measured number, within the range that was stated.
By their numbers in this assay, from the lowest: compound 1; then compounds 3 and 2 (each within the scatter of the next).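

In this assay, hydrogen in place of methoxy on this aromatic carbon, meta and para to a fused ring, gives a 1.7-fold lower number from compound 2 to compound 3 (0.23 log units; within the scatter), so this position does not distinguish the two groups. The same kind of exchange on the other aromatic carbon that carries methoxy in this set gives a 5.0-fold higher number from compound 1 to compound 3 (0.70 log units; beyond the scatter), so across these three compounds the effect of losing a methoxy group depends on where it sits. Nothing at hand explains either result.

As far as these compounds go, only methoxy and hydrogen are seen on the fused ring, so it remains open whether a hydroxyl group, a chlorine atom or an amine there would move the number beyond the scatter. From the compounds shown here alone, it is also open whether groups such as these would match methoxy on the other ring, where the exchange does register.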